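Methyl on the ring nitrogen in two matched pairs

The compounds below may be only part of what the source reports. "The series", "measured", "known", "first", "only" and "open" are said of these compounds alone.

Compound 1 `O=C1NC(=O)/C(=C/C2=Cc3ccccc3OC2)S1` opens the first pair. In a functional assay on K562 cells (Homo sapiens) for antiproliferative activity, read by MTT assay, with a stated time of 72 h (on this read-out lower numbers stand for stronger inhibition and higher numbers for weaker inhibition), compound 1 gives 98900 nM. Compound 2 `CN1C(=O)S/C(=C\C2=Cc3ccccc3OC2)C1=O` carries methyl in place of hydrogen on an amide-type nitrogen in a ring. In this assay compound 2 reaches only a limit, > 100000 nM. The step from the parent to the methylated analogue is a number no lower from compound 1 to compound 2 (the limit leaves the size open); its size stays hidden because the limit of > 100000 nM in this assay, at which 1 of the 3 values shown sits, is what the methylated compound returns.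

Compound 3 `CC1Oc2ccc(Br)cc2C=C1/C=C1\SC(=O)NC1=O` belongs to a second core; the difference between the core of compound 1 and the core of compound 3 is not broken down here. In this assay compound 3 gives 77000 nM, a number within the scatter of what compound 1 shows, so no order between the two is claimed.

Compound 4 `CC1Oc2ccc(Br)cc2C=C1/C=C1\SC(=O)N(C)C1=O` has not been measured. Within the data shown here, it carries methyl in place of hydrogen on an amide-type nitrogen in a ring, the same structural change as the one from compound 1 to compound 2, at the same place. The step is expected to be a 1.9-fold higher number from compound 3 to compound 4 (0.29 log units; within the scatter), resting on the earlier step of a number no lower from compound 1 to compound 2 (the limit leaves the size open). Compound 4 is estimated at 150000 nM in this assay, with the range 60000 nM to 400000 nM, and a real chance that only a limit is reported.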

Compound 4, half-maximal inhibitory concentration: > 50000 nM
Compound 4: a limit, no number; the forecaster's own chance of this, stated with the estimate: 65%; the middle value does not contradict the limit.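

Compound 4 returns only a limit in this assay, so no step from compound 3 to compound 4 can be read: the limit of > 50000 nM in this assay, at which 1 of the 4 values shown sits.

The compounds shown leave open whether methyl in place of hydrogen on the ring nitrogen changes the antiproliferative number in either core; neither matched pair gives a readable size.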